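The source may report more compounds than this note shows. Statements on the series, on what has been measured and on what is new or still open speak of the compounds shown alone.

In a functional assay on SK-MEL-28 cells (Homo sapiens) for inhibition, read by MTT assay, with a stated time of 48 h; a higher number here means a weaker inhibitor, a lower number a stronger inhibitor:
- Compound 1 `CCc1ccc(-c2nc3ccccn3c2Sc2ccccc2)cc1`: > 100000 nM, a limit of the assay and not a number
- Compound 2 `COc1ccc(-c2nc3ccccn3c2Sc2ccccc2)cc1`: 83900 nM

Going by the values given here, compound 2 holds the only true number here, so there is little to compare it with. Compound 3 `C(=C/c1nc2ccccn2c1Sc1ccccc1)\c1ccccc1` carries 2-phenylethenyl in place of 4-methoxyphenyl on an aromatic carbon. Among the compounds with values here, the single measured step, an at least 1.1-fold lower number from compound 1 to compound 2 (0.07 log units; that floor lies within the scatter), rests on the limit of > 100000 nM in this assay, at which 1 of the 2 values shown sits, and is the only guide. It shows no change beyond the scatter, so no clear step is expected in this assay for this swap. The estimated step is a 1.2-fold lower number from compound 2 to compound 3 (0.08 log units; within the scatter). The expected value for compound 3 is 70000 nM, with an estimated range of 20000 nM to 200000 nM.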

Compound 3, half-maximal inhibitory concentration: 65400 nM
Beside the measured number, compound 3's estimate is 1.1-fold (0.03 log units) above it, within the range that was stated.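

Swapping 4-methoxyphenyl for 2-phenylethenyl at this position brings in a double bond outside aromatic rings and removes the oxygen, yet this assay shows no clear change, with a 1.3-fold lower number from compound 2 to compound 3 (0.11 log units; within the scatter). The other new step gives only a floor, an at least 1.5-fold lower number from compound 1 to compound 3 (0.18 log units; that floor lies within the scatter). That floor rests on a limit of the assay and not a number: the limit of > 100000 nM in this assay, at which 1 of the 3 values shown sits.

As far as these compounds go, whether an amine, a carboxylic acid or a longer chain at this position would move the number beyond the scatter stays open. So does the effect of changing the phenylsulfanyl group.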